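A few compounds are considered here, and "the series" means these few. Any claim that something is new, unique, unknown or untested is made for them only; others in the source may bear on it.

Measured compounds in a functional assay on A498 cells (Homo sapiens) for inhibition, read by sulforhodamine B assay, with a stated time of 48 h; on this read-out lower numbers stand for stronger inhibition of growth and higher numbers for weaker inhibition of growth:
Compound 1 `Nc1cc(N)c2nc(-c3ccccc3)c(Oc3ccc(Cl)c(Cl)c3)nc2c1`: compound 1 gives only a limit, < 100000 nM.
Compound 2 `Nc1cc(N)c2nc(-c3ccccc3)c(NCc3ccc(Cl)c(Cl)c3)nc2c1`: compound 2 gives 32400 nM.
Compound 3 `Nc1cc(N)c2nc(-c3ccccc3)c(NCc3ccc(F)cc3)nc2c1`: compound 3 gives 30900 nM.

Compound 3 holds the lowest of the two numbers, with compound 2 nearest; the step of a 1.0-fold lower number from compound 2 to compound 3 (0.02 log units; within the scatter) lies within the scatter. Compound 1 sits at the limit (the limit of < 100000 nM in this assay, at which 1 of the 3 values shown sits), so the step that the limit leaves unreadable from compound 1 to compound 3 cannot be sized.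

Compound 4 `COc1ccc(CNc2nc3cc(N)cc(N)c3nc2-c2ccccc2)cc1` differs from compound 3 by methoxy in place of fluoro on an aromatic carbon. Among the measured compounds shown here, the only measured step touching the same benzyl group, a 1.0-fold lower number from compound 2 to compound 3 (0.02 log units; within the scatter), was within the scatter, so no step beyond the scatter is expected in this assay in either direction. The step of a 1.0-fold lower number from compound 3 to compound 4 (0.01 log units; within the scatter) is the expected outcome. Compound 4 is expected to give 30000 nM, within a range of 12000 nM to 80000 nM.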

Compound 4, concentration for total growth inhibition: < 100000 nM
Compound 4 was reported as a limit; the forecaster's own chance of this, stated with the estimate: 10%; the middle value does not contradict the limit.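

Among the compounds shown here, compound 4 is reported only as a limit, so no new step from compound 2 or compound 3 to compound 4 can be read: the limit of < 100000 nM in this assay, at which 2 of the 4 values shown sit. As far as these compounds go, whether methoxy in place of fluoro shifts growth inhibition stays open.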